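The source may hold more compounds than are shown below. What is called first, only, known or untested is meant among the compounds shown, and "the series" means these compounds.

Working notes on the series.

Compound 2 `CCOc1ccccc1N1CCN(C(=S)SCc2nc3cc(C)c(C)cc3[nH]2)CC1` gives 5580 nM in a functional assay on MCF7 cells (Homo sapiens) for cytotoxicity, read by MTT assay, with a stated time of 24 h; on this read-out lower numbers stand for stronger inhibition and higher numbers for weaker inhibition. Compound 1 `COc1ccc(N2CCN(C(=S)SCc3nc4cc(C)c(C)cc4[nH]3)CC2)cc1`, carrying the change (4-methoxyphenyl in place of 2-ethoxyphenyl on an amine nitrogen in a ring), gives 46000 nM; the measured step is an 8.2-fold higher number from compound 2 to compound 1 (0.92 log units; beyond the scatter). Compound 3 `CCOc1ccccc1N1CCN(CCCSc2nc3cc(Cl)ccc3[nH]2)CC1` gives 27700 nM; its values against compound 1 lie within the scatter, while against compound 2 it stands beyond it. The difference between the cores of compound 2 and compound 3 is not broken down here.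

Compound 4 `COc1ccc(N2CCN(CCCSc3nc4cc(Cl)ccc4[nH]3)CC2)cc1` differs from compound 3 by 4-methoxyphenyl in place of 2-ethoxyphenyl on an amine nitrogen in a ring, the same kind of change as that from compound 2 to compound 1. Resting on the single prior example an 8.2-fold higher number from compound 2 to compound 1 (0.92 log units; beyond the scatter), a weakening of similar size is expected, about a 5.4-fold higher number from compound 3 to compound 4 (0.73 log units; beyond the scatter), with uncertainty since the core is different and only one instance is known. Compound 4 is thus estimated at 150000 nM, expected between 45000 nM and 400000 nM.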

Compound 4, half-maximal inhibitory concentration: 38500 nM
Compound 4: middle estimate off by 3.9-fold (0.59 log units), on the high side; the measured number lies below the stated range.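

In this assay, the change from 2-ethoxyphenyl to 4-methoxyphenyl gives a 1.4-fold higher number from compound 3 to compound 4 (0.14 log units; within the scatter). The size of the step does not carry over from one core to the other: the same change on two cores in this assay, an 8.2-fold higher number (0.92 log units; beyond the scatter) from compound 2 to compound 1 and a 1.4-fold higher number (0.14 log units; within the scatter) from compound 3 to compound 4, 5.9-fold (0.77 log units) apart, beyond the scatter of two such steps. With one pair on each core, this shows that the earlier step cannot be applied unchanged to a new core in this series, but it does not show which difference between the cores matters, or how the step would read on a third core.

The compounds shown leave open whether 2-methoxyphenyl or 4-ethoxyphenyl on the same ring nitrogen would follow compound 2 or compound 3 on each core. They also leave open which of the two changes within the swap, the group or its ring position, carries the larger step on the core of compound 2.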